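This account rests on a few compounds, and the source may have more. Where it says the series, first, only, none or still open, it means among the compounds named here.

Working notes on the series of bis-arylidene compounds sharing the core of compound 1 `COc1cc(/C=C2\CN(C)C/C(=C\c3cc(OC)c(OC)c(OC)c3)C2=O)cc(OC)c1`. In a functional assay on HepG2 cells (Homo sapiens) for cytotoxicity, read by MTT assay, with a stated time of 24 h (on this read-out lower numbers stand for stronger inhibition and higher numbers for weaker inhibition), compound 1 gives 890 nM. Compound 2 `COc1cc(/C=C2\CN(C)C/C(=C\c3ccc(Cl)cc3)C2=O)cc(OC)c1OC` gives 8250 nM in this assay, and compound 3 `COc1cc(/C=C2\CN(C)C/C(=C\c3ccc(Cl)cc3Cl)C2=O)cc(OC)c1OC` gives 8800 nM. Compound 3 therefore holds the highest of the three numbers: its nearest neighbour is compound 2, at a gap that a 1.1-fold higher number from compound 2 to compound 3 (0.03 log units; within the scatter) places within the scatter, and its furthest is compound 1, with a 9.9-fold higher number from compound 1 to compound 3 (1.00 log units; beyond the scatter) beyond the scatter.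

Compound 4 `COc1cc(/C=C2\CN(C)C/C(=C\c3ccc(C#N)cc3)C2=O)cc(OC)c1OC` is not yet measured in this assay. The change from compound 3 is 4-cyanophenyl in place of 2,4-dichlorophenyl on a double-bonded chain carbon bound to a double-bonded ring carbon. Of the measured steps, a 9.3-fold higher number from compound 1 to compound 2 (0.97 log units; beyond the scatter) and a 9.9-fold higher number from compound 1 to compound 3 (1.00 log units; beyond the scatter) both concern replacement of the 3,5-dimethoxyphenyl with a chlorinated phenyl and are of similar size, while a 1.1-fold higher number from compound 2 to compound 3 (0.03 log units; within the scatter) shows that adding the second chloro changed nothing beyond the scatter. For the measured compounds named here, no measured step compares 4-cyanophenyl with a chlorinated phenyl, so the step to compound 4 is expected to stay within the scatter, with compound 4 remaining near compound 2 and compound 3 rather than returning toward compound 1. The expected step is a 1.3-fold lower number from compound 3 to compound 4 (0.10 log units; within the scatter). For compound 4 the estimate in this assay is 7000 nM, with a range from 3000 nM to 18000 nM.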

Compound 4, half-maximal inhibitory concentration: 1140 nM
The estimate for compound 4 lay 6.1-fold (0.79 log units) above the measured number; measured number outside the range, below it.
By their numbers in this assay, from the lowest: compounds 1 and 4 (each within the scatter of the next); then compounds 2 and 3 (each within the scatter of the next).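

In this assay, the place on a double-bonded chain carbon bound to a double-bonded ring carbon responds to which group the phenyl carries, and not simply to the loss of the 3,5-dimethoxyphenyl: cyano in place of chloro on an aromatic carbon gives a 7.2-fold lower number from compound 2 to compound 4 (0.86 log units; beyond the scatter), and 4-cyanophenyl in place of 2,4-dichlorophenyl gives a 7.7-fold lower number from compound 3 to compound 4 (0.89 log units; beyond the scatter). Leaving the 3,5-dimethoxyphenyl therefore does not always raise the number, since 4-cyanophenyl in its place gives a 1.3-fold higher number from compound 1 to compound 4 (0.11 log units; within the scatter), so these two groups cannot be told apart here, while compound 2 and compound 3 stand apart from both. Nothing available bears on the cause of this difference, so it stands as an observation only.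

Going by these compounds, it remains open whether a carboxylic acid or an amine on the phenyl at this place would give a number close to that of compound 4 or close to that of compound 2. On these data alone, it is also open whether cyano in place of chloro gives a step of this size on any other member of the series.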